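The source may report more compounds than this note shows. Statements on the series, on what has been measured and on what is new or still open speak of the compounds shown alone.

Measured so far in a functional assay on MDA-MB-231 cells (Homo sapiens) for antiproliferative activity, read by MTT assay, with a stated time of 72 h; a lower number here means a stronger inhibitor, a higher number a weaker inhibitor:
Compound 1 `CC(C)(C)c1ccc(OCCCON2C(N)=NC(N)=NC23CCSCC3)cc1`: 1 nM
Compound 2 `COc1ccc(OCCCON2C(N)=NC(N)=NC23CCOCC3)cc1`: "not determined" (no result reported)
Compound 3 `NC1=NC2(CCSCC2)N(OCCCOc2cccc(Cl)c2)C(N)=N1`: 130 nM

Compound 2 offers no number to work from. In this assay, as far as these compounds go, compound 2 is recorded as "not determined" (no result reported), so its place relative to the other two compounds is unknown. Those two lie far apart, with compound 1 at 1 nM and compound 3 at 130 nM. They share a core that differs from the core of compound 2.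

Compound 4 `NC1=NC2(CCOCC2)N(OCCCOc2cccc(Cl)c2Cl)C(N)=N1` has not yet been measured. The structural change is 2,3-dichlorophenyl in place of 4-methoxyphenyl on an oxygen on a saturated carbon, with the core left as it is. For the measured compounds named here, no measured step between compounds differing in one place is available, and no step can be read from compound 2, so any expectation rests on thin evidence.

The nearest guide is compound 3 at 130 nM, which also carries chlorine on its aromatic ring, though on a different core. Compound 4 is therefore expected to fall near that value in this assay, with no step beyond the scatter, and on the weaker side of compound 1 at 1 nM. The estimate for compound 4 is 150 nM, with an expected range from 30 nM to 800 nM.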

Compound 4, half-maximal inhibitory concentration: 140 nM
Compound 4: middle estimate off by 1.1-fold (0.03 log units), on the high side; the range from low to high includes it.
By their numbers in this assay, from the lowest: compound 1; then compounds 3 and 4 (each within the scatter of the next).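

In this assay, for the compounds shown here, compound 2 is recorded as "not determined" (no result reported) so no step from it to compound 4 can be read. The compounds shown leave open how the exchange of 4-methoxyphenyl for 2,3-dichlorophenyl acts on its own, and how the core of compound 4 compares with that of compound 3. No evidence bearing on the result of compound 4 is available.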